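Cytotoxicity notes on the fluorinated-chain series

The source may report more compounds than this note shows. Statements on the series, on what has been measured and on what is new or still open speak of the compounds shown alone.

Compound 1 `Cc1nc2nc(-c3ccccc3)cc(C(F)(F)F)c2c(=O)n1Cc1cn(CCC(F)(F)C(F)(F)C(F)(F)C(F)(F)C(F)(F)C(F)(F)F)nn1` carries the shared core with a short fluorinated chain on the triazole-side nitrogen. In a functional assay on THP-1 cells (Homo sapiens) for cytotoxicity, read by MTT assay, with a stated time of 24 h (a lower number here means a stronger inhibitor, a higher number a weaker inhibitor), compound 1 reports only a limit, > 200 ug/mL. Compound 2 `Cc1nc2nc(-c3ccccc3)cc(C(F)(F)F)c2c(=O)n1Cc1cn(CCC(F)(F)C(F)(F)C(F)(F)C(F)(F)C(F)(F)C(F)(F)C(F)(F)C(F)(F)F)nn1` lengthens that chain. In this assay compound 2 also reports only a limit, > 200 ug/mL. The step that the two limits leave unreadable from compound 1 to compound 2 therefore cannot be read. Compound 3 `Cc1nc2nc(-c3ccccc3)cc(C(F)(F)F)c2c(=O)n1Cc1cn(-c2ccccc2)nn1` replaces the chain with a phenyl group. In this assay compound 3 sits at the limit as well, > 200 ug/mL. Every value gathered so far is a limit, namely (the limit of > 200 ug/mL in this assay, at which 3 of the 3 values shown sit).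

Compound 4 `CCc1nc2nc(-c3ccccc3)cc(C(F)(F)F)c2c(=O)n1Cc1cn(CCC(F)(F)C(F)(F)C(F)(F)C(F)(F)C(F)(F)C(F)(F)C(F)(F)C(F)(F)F)nn1` is not yet measured. It differs from compound 2 by methyl in place of hydrogen on a saturated chain carbon bound to an aromatic carbon; cut one bond further out, the change reads methyl to ethyl. Going by the values given here, no measured step touches this position, and the single measured step has both ends at the limit, giving no size in either direction. With all three values sitting at the limit of > 200 ug/mL in this assay, at which 3 of the 3 values shown sit, nothing in the series points to a stronger or weaker inhibitor for compound 4. Compound 4 is expected to remain at the limit in this assay, with the step that the limit leaves unreadable from compound 2 to compound 4 expected to lie within scatter. The estimate for compound 4 is 400 ug/mL, between 150 ug/mL and 1500 ug/mL.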

Compound 4, half-maximal inhibitory concentration: > 200 ug/mL
Compound 4: a limit, no number (the forecaster's own chance of this, stated with the estimate: 85%); the middle value lies beyond the limit too.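

In this assay compound 4 gives > 200 ug/mL, which is a limit and not a number. Compound 2 also reports only a limit, so the step to compound 4 cannot be read. The compounds shown leave open whether any of these structural changes alters the half-maximal inhibitory concentration, as all values stand at one limit: the limit of > 200 ug/mL in this assay, at which 4 of the 4 values shown sit.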